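Swapping the Chain Sulfonamide for an Aminopyrazine

A few compounds are considered here, and "the series" means these few. Any claim that something is new, unique, unknown or untested is made for them only; others in the source may bear on it.

Measured compounds:
compound 1, `CCN1CCN(c2cccc3c2CN([C@H](CCCNS(=O)(=O)c2c[nH]cn2)c2ccc(OC)c(OC)c2)C3=O)CC1`: 25 nM
compound 2, `CCN1CCN(c2cccc3c2CN([C@H](CCCN(C)S(=O)(=O)c2cccs2)c2ccc(OC)c(OC)c2)C3=O)CC1`: < 5 nM
compound 3, `COc1ccc([C@@H](CCCN(C)S(=O)(=O)c2cccs2)N2Cc3c(cccc3N3CCNCC3)C2=O)cc1OC`: 49 nM

In an assay on RMS13 cells for displacement of a labelled ligand from Urotensin-2 receptor (Homo sapiens), read by scintillation proximity assay (a lower number here means a stronger inhibitor, a higher number a weaker inhibitor), compound 2 is reported only as a limit, < 5 nM, which is the limit of < 5 nM in this assay, at which 1 of the 3 values shown sits. Compound 1 gives 25 nM and compound 3 gives 49 nM in this assay, and both steps to compound 2 are beyond the scatter, so compound 2 stands as the strongest of the three.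

Compound 4, `CCN1CCN(c2cccc3c2CN([C@H](CCCNc2cncc(OC)n2)c2ccc(OC)c(OC)c2)C3=O)CC1`, differs from compound 2 by (6-methoxypyrazin-2-yl)amino in place of methyl((thiophen-2-yl)sulfonyl)amino on a saturated chain carbon, four bonds along the chain from an amide-type nitrogen in a ring and an aromatic carbon. For the measured compounds named here, only one measured step touches this part of the molecule: an at least 5.0-fold lower number from compound 1 to compound 2 (0.69 log units; beyond the scatter), which shows that the group at this chain position can move the number by a clear margin. The step of an at least 9.8-fold higher number from compound 2 to compound 3 (0.99 log units; beyond the scatter) concerns a different site and says nothing about the chain end. Since compound 2 sits at a limit, the true size of any step from it is uncertain. Compound 4 is expected to lose ground, an at least 6.0-fold higher number from compound 2 to compound 4 (0.77 log units; beyond the scatter). The estimate for compound 4 is 30 nM, with a range from 5 nM to 200 nM.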

Compound 4, inhibition constant: 8 nM
Compound 4: the middle estimate sits 3.8-fold (0.57 log units) above what was measured; low and high end bracket the measured number.
By their numbers in this assay, from the lowest: compound 4; then compounds 1 and 3 (each within the scatter of the next). At a limit, below all of these: compound 2.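

Until now the chain end had carried only sulfonyl groups, and compound 4 shows that a group with no sulfonyl at all, (6-methoxypyrazin-2-yl)amino, can hold this position in this assay and do better than the imidazole sulfonamide: a 3.1-fold lower number from compound 1 to compound 4 (0.49 log units; beyond the scatter). Against the thiophene sulfonamide the comparison gives an at least 1.6-fold higher number from compound 2 to compound 4 (0.20 log units; that floor lies within the scatter), so the data do not establish any real loss on leaving that group, and the two cannot be placed in order. Compound 2 remains a limit and not a number: the limit of < 5 nM in this assay, at which 1 of the 4 values shown sits.

On these data alone, what a plain pyrazin-2-ylamino group without the methoxy, or a longer chain, would do at this position remains open. Also open, as far as these compounds go, is whether replacing ethyl with hydrogen on the ring amine nitrogen would cost as much with the aminopyrazine as it does with the sulfonamide.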